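The source may hold more compounds than are shown below. What is called first, only, known or untested is meant among the compounds shown, and "the series" means these compounds.

In a functional assay on Caco-2 cells (Homo sapiens), read by fluorescence, tested at 1 uM (on this read-out higher numbers stand for a weaker effect at the one concentration tested and lower numbers for a stronger effect), compound 1 `CCCNC(=C\C(=O)/C=C/c1ccc(O)c(OC)c1)/C=C/c1ccc(O)c(OC)c1` gives 97%. Compound 2 `COc1cc(/C=C/C(=O)CC(=O)/C=C/c2ccc(OC(C)=O)c(OC)c2)ccc1OC(C)=O` gives 93% in this assay. Compound 1 thus carries the larger of the two numbers in hand, yet its gap to compound 2 falls within the scatter, so the two cannot be told apart on these data. Compound 3 `COc1cc(/C=C/C(=O)/C=C(/C=C/c2ccc(O)c(OC)c2)NCC(C)C)ccc1O` is the next step from compound 1: methyl in place of hydrogen on a saturated chain carbon bound to two saturated chain carbons. Among the measured compounds shown here, no measured pair shows what this change does, and the expected step is a number 2 percentage points lower from compound 1 to compound 3 (within the scatter), within the scatter and with no direction called. Compound 3 is estimated at 95% in this assay, with a range of 80% to 105%.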

Compound 3, a percentage reported as activity, at one concentration (the size of the read-out at that concentration, not a potency): 91%
The estimate for compound 3 lay 4 percentage points above the measured number; low and high end bracket the measured number.
By their numbers in this assay, from the lowest: compounds 3, 2 and 1 (each within the scatter of the next).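

Propylamino to isobutylamino is the first single-place change that can be read in this assay: methyl in place of hydrogen on this saturated chain carbon gives a number 6 percentage points lower from compound 1 to compound 3 (within the scatter). The two compounds therefore cannot be told apart, and this one change leaves the read-out inside the usual scatter. No available evidence bears on this step.

Going by these compounds, whether a longer chain such as hexyl, or a carboxylic acid at the end of the chain, would give a step beyond the scatter remains open. A single pair also leaves open whether the same methyl change would read alike on another core.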